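Ring Expansion on a Shared Core and Expected Lipophilicity

The source may hold more compounds than are shown below. What is called first, only, known or untested is meant among the compounds shown, and "the series" means these compounds.

Measured compounds:
compound 1 `COc1cc(Br)cc(-c2noc(C3CCCN3C)n2)c1OC`: 3.79
compound 2 `COc1cc(Br)cc(-c2noc(C3CCCN(Cc4ccccc4)C3)n2)c1OC`: 5.81

In a physicochemical assay for lipophilicity (on this read-out higher numbers stand for higher lipophilicity and lower numbers for lower lipophilicity), compound 1 stands lowest of the two numbers; compound 2 gives the higher number, and the gap between them lies beyond the scatter. Compound 3 `COc1cc(Br)cc(-c2noc(C3CCCCN3C)n2)c1OC` differs from compound 1 in one place: 1-methylpiperidin-2-yl in place of 1-methylpyrrolidin-2-yl on an aromatic carbon. Going by the values given here, no step of this kind has been measured here, so the size of the change is not known from the data. For compound 3 a modest rise in this assay is expected, a number 0.41 log units higher from compound 1 to compound 3 (beyond the scatter). Compound 3 is therefore estimated at 4.2, within a range from 3.9 to 4.6.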

Compound 3, partition coefficient: 4.21
Compound 3: the middle estimate sits 0.01 log units below what was measured; low and high end bracket the measured number.
By their numbers in this assay, from the lowest: compound 1; then compound 3; then compound 2.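

In this assay, 1-methylpiperidin-2-yl in place of 1-methylpyrrolidin-2-yl on an aromatic carbon gives a number 0.42 log units higher from compound 1 to compound 3 (beyond the scatter). Going by these compounds alone, this is the first single-place step at this position, so the position now has a measured change, and one that clears the scatter. No measurement presented here accounts for the size of this step. The compounds shown leave open how 1-methylazetidin-2-yl or 1-methylazepan-2-yl would read at this position in this assay, and so whether the step continues with other ring sizes.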